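The compounds below may be only part of what the source reports. "The series", "measured", "known", "first", "only" and "open" are said of these compounds alone.

Compound 1 `CC(C)(C)Oc1ccc2nc(N)sc2c1`; compound 2 `CC(C)(C)c1ccc2nc(N)sc2c1`; compound 3 `CCN(CC)C(=O)Cn1c(=N)sc2cc(OC(F)(F)F)ccc21`.

In a functional assay on the whole organism with Rattus norvegicus as the target (a lower number here means that less compound is needed, a higher number that more compound is needed for the effect), compound 2 gives 4 mg/kg and compound 3 gives 9 mg/kg. For compound 1 this assay reports only a limit, > 10 mg/kg. Among the two actual numbers, compound 3 stands highest; compound 2 is the nearest. Among the measured compounds shown here, the one step measured between two compounds, an at least 2.5-fold lower number from compound 1 to compound 2 (0.39 log units; beyond the scatter), concerns a group on an aromatic carbon; its size is at least modest, and the limit of > 10 mg/kg in this assay, at which 1 of the 3 values shown sits, is all that is known of its starting point.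

Compound 4 `CS(=O)(=O)CCn1c(=N)sc2cc(OC(F)(F)F)ccc21` differs from compound 3 by (methylsulfonyl)methyl in place of diethylcarbamoyl on a saturated chain carbon bound to an aromatic nitrogen. For the measured compounds named here, this change sits on the saturated chain carbon bound to an aromatic nitrogen, a place untouched by the measured step, so no measured step bears on it directly and no direction can be read from the data. The step of no change at the digits printed from compound 3 to compound 4 (within the scatter) is therefore expected to stay within the scatter. Compound 4 is estimated to give 9 mg/kg, with a range from 4 mg/kg to 20 mg/kg.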

Compound 4, dose for half-maximal effect: 1.8 mg/kg
Compound 4: the middle estimate sits 5.0-fold (0.70 log units) above what was measured; the measured number lies below the stated range.
By their numbers in this assay, from the lowest: compound 4; then compound 2; then compound 3. At a limit, above all of these: compound 1.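

In this assay the exchange of diethylcarbamoyl for (methylsulfonyl)methyl gives a 5.0-fold lower number from compound 3 to compound 4 (0.70 log units; beyond the scatter) and so shows that the group at this place can change the dose needed. Among the compounds shown here, the earlier step concerned a group on an aromatic carbon, so this is the only measured step on a saturated chain carbon bound to an aromatic nitrogen, and its direction could not be read from anything before it. The compounds shown offer no measurement that explains why the number falls with this change.

Going by these compounds, it stays open whether the drop comes from gaining the methylsulfonyl group or from losing diethylcarbamoyl, since a single exchange does both at once. On these data alone, how a carboxylic acid, an amine or a longer chain ending in the same methylsulfonyl group would behave at this place also remains unknown.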